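Methyl for hydrogen on the phenolic oxygen, second pair

This account rests on a few compounds, and the source may have more. Where it says the series, first, only, none or still open, it means among the compounds named here.

Compound 1 `O=C(Nc1cccc(-n2cc(-c3ccncc3)c(-c3cc(O)cc(Cl)c3)n2)c1)Nc1ccc(Cl)c(C(F)(F)F)c1` and compound 2 `COc1cc(Cl)cc(-c2nn(-c3cccc(NC(=O)Nc4ccc(Cl)c(C(F)(F)F)c4)c3)cc2-c2ccncc2)c1` share one core and differ in a single place, (methyl in place of hydrogen on an oxygen on an aromatic ring). In a functional assay on MOLT-4 cells (Homo sapiens) for inhibition, read by sulforhodamine B assay, with a stated time of 48 h, tested at 10 uM (a higher number here means a weaker effect of the compound at the concentration tested, a lower number a stronger effect), compound 1 gives -18%, and compound 2 gives -9.68%. The step of a number 8.3 percentage points higher from compound 1 to compound 2 (within the scatter) is small, so the two numbers cannot be told apart in this assay.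

Compound 3 `O=C(Nc1cccc(-n2cc(-c3ccncc3)c(-c3cc(O)cc(Cl)c3)n2)c1)c1cc(C(F)(F)F)cc(C(F)(F)F)c1` carries a different core; the difference between the two cores is not broken down here. In this assay compound 3 gives 19.5%, which stands highest of the three measured numbers and lies beyond the scatter from both compound 1 and compound 2.

Compound 4 `COc1cc(Cl)cc(-c2nn(-c3cccc(NC(=O)c4cc(C(F)(F)F)cc(C(F)(F)F)c4)c3)cc2-c2ccncc2)c1` has not yet been measured. It differs from compound 3 by methyl in place of hydrogen on an oxygen on an aromatic ring. The place is described in the same words for both pairs, on an oxygen on an aromatic ring whose other neighbours are aromatic carbon, so the change is the same one as between compound 1 and compound 2, made on the other core. Among the measured compounds shown here, its only measured instance, a number 8.3 percentage points higher from compound 1 to compound 2 (within the scatter), is within the scatter, and nothing in the data shows that the core of compound 3 answers to it differently. For compound 4 a step of a number 6.5 percentage points higher from compound 3 to compound 4 (within the scatter) is therefore expected, of the same kind and size as the earlier one, resting on that single measured step. Compound 4 is estimated at 26% in this assay, with most repeats expected to fall between 8% and 44%.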

Compound 4, a percentage reported as activity, at one concentration (the size of the read-out at that concentration, not a potency): 55.3%
Compound 4: middle estimate off by 29.3 percentage points, on the low side, outside the stated range (above it).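

Working from the two pairs in this assay, the change from 3-chloro-5-hydroxyphenyl to 3-chloro-5-methoxyphenyl does not carry over at one size from one core to the other: the same change on two cores in this assay, a number 8.3 percentage points higher (within the scatter) from compound 1 to compound 2 and a number 35.8 percentage points higher (beyond the scatter) from compound 3 to compound 4, 27.5 percentage points apart, beyond the scatter of two such steps

Among the compounds shown here, the single measured step on the first core was therefore no safe guide to the second, where the result is a number 35.8 percentage points higher from compound 3 to compound 4 (beyond the scatter), a clearly weaker effect at the concentration tested. This shows that the size of the step depends on the core in this small set, but it does not show which part of the difference between the two cores is responsible, and with one pair per core and a single concentration it gives no general rule for either core.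

The compounds shown carry only hydroxy and methoxy at this place, so it remains open how a longer chain such as ethoxy, or an amine in place of the oxygen, would read on each core. From the compounds shown here alone, it also remains open whether a further core would give a small step or a large one for the same change from hydrogen to methyl on the oxygen.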